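Working notes: swapping methyl for chloro on compound 1

The compounds below may be only part of what the source reports. "The series", "measured", "known", "first", "only" and "open" are said of these compounds alone.

Values in a functional assay on A549 cells (Homo sapiens) for antiproliferative activity, read by MTT assay, with a stated time of 48 h; a higher number here means a weaker inhibitor, a lower number a stronger inhibitor:
- compound 1 `Cc1ccc2nc(NC(c3cn(-c4ccccc4)nc3-c3cccc([N+](=O)[O-])c3)c3c(O)ccc4ccccc34)sc2c1`: 57400 nM
- compound 2 `Cc1ccc2nc(NC(c3cn(-c4ccccc4)nc3-c3cccc(Cl)c3)c3c(O)ccc4ccccc34)sc2c1`: 45400 nM
- compound 3 `Oc1ccc2ccccc2c1C(Nc1nc2ccccc2s1)c1cn(-c2ccccc2)nc1-c1cccc(Cl)c1`: 20400 nM

Compound 1 sits level with compound 2 within the scatter, at the weak end of this small set, and only compound 3 lies clearly lower. Compound 4 `O=[N+]([O-])c1cccc(-c2nn(-c3ccccc3)cc2C(Nc2nc3ccc(Cl)cc3s2)c2c(O)ccc3ccccc23)c1` keeps the nitro group of compound 1 and differs in one place: chloro in place of methyl on an aromatic carbon, giving 6-chloro-1,3-benzothiazol-2-yl from 6-methyl-1,3-benzothiazol-2-yl.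

Among the measured compounds shown here, no measured step makes this exact swap. The closest is a 2.2-fold lower number from compound 2 to compound 3 (0.35 log units; beyond the scatter), where the same methyl leaves for hydrogen, and that step is modest. The other, a 1.3-fold lower number from compound 1 to compound 2 (0.10 log units; within the scatter), brings in chloro elsewhere, in place of nitro, and stays within the scatter. A small fall in the number is therefore expected in this assay, possibly none beyond the scatter. The expected step is a 1.5-fold lower number from compound 1 to compound 4 (0.18 log units; within the scatter).

For compound 4 the estimated value is 38000 nM, with an expected range of 17000 nM to 80000 nM.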

Compound 4, half-maximal inhibitory concentration: 42500 nM
For compound 4 the middle estimate is 1.1-fold (0.05 log units) below the measured one; the measured number falls inside the stated range.
By their numbers in this assay, from the lowest: compound 3; then compounds 4, 2 and 1 (each within the scatter of the next).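

In this assay, chloro in place of methyl with the nitro group kept gives a 1.4-fold lower number from compound 1 to compound 4 (0.13 log units; within the scatter), so 6-chloro-1,3-benzothiazol-2-yl and 6-methyl-1,3-benzothiazol-2-yl cannot be told apart in this assay when nitro is present. The earlier compounds shown here showed only the loss of the methyl, a 2.2-fold lower number from compound 2 to compound 3 (0.35 log units; beyond the scatter), in compounds carrying chloro rather than nitro; this result adds that a substituent exchange at this position need not give a step beyond the scatter. Nothing available explains why the two groups read alike.

As far as these compounds go, whether a methoxy group, an amine or a carboxylic acid at this position would read differently remains open. Also open, from the compounds shown here alone, is whether the step seen on removing the methyl carries over to compounds that keep the nitro group.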